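Dropping the Hydroxyl: Compound 3 Expected to Weaken

The source may hold more compounds than are shown below. What is called first, only, known or untested is meant among the compounds shown, and "the series" means these compounds.

Compound 2 `Cc1c(C(=O)N/N=C\c2cc(F)ccc2O)oc2cccc(O)c12` is the stronger of the two measured compounds: in a functional assay on PC-3 cells (Homo sapiens) for inhibition (on this read-out lower numbers stand for stronger inhibition and higher numbers for weaker inhibition), compound 2 gives 3170 nM, whereas compound 1 `Cc1c(C(=O)N/N=C\c2ccccc2O)oc2cccc(O)c12` gives 8350 nM. Within the data shown here, the only measured step, a 2.6-fold lower number from compound 1 to compound 2 (0.42 log units; beyond the scatter), lies beyond the scatter and concerns solely the introduction of fluorine.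

Compound 3 `Cc1c(C(=O)N/N=C\c2ccc(F)cc2)oc2cccc(O)c12` differs from compound 2 by 4-fluorophenyl in place of 5-fluoro-2-hydroxyphenyl on a carbon with a double bond to nitrogen. The hydroxyl group present in compound 2 is thus absent in compound 3, while a fluorine is retained in a different arrangement. Among the measured compounds shown here, no measured step speaks to the removal of the hydroxyl; the step from compound 1 to compound 2 bears on compound 3 only insofar as compound 3 still carries a fluorine. A step in this assay is therefore expected, and the loss of the hydrogen-bond donor and acceptor counted above makes a move toward weaker inhibition the more likely direction, estimated as a 2.8-fold higher number from compound 2 to compound 3 (0.45 log units; beyond the scatter). Compound 3 is accordingly expected to give 9000 nM in this assay, with a range from 3000 nM to 30000 nM.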

Compound 3, half-maximal inhibitory concentration: >= 40000 nM
Compound 3: no number, only a limit (the forecaster's own chance of this, stated with the estimate: 20%); middle value at least 4.4-fold (0.64 log units) away from the limit.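

Compound 3 gives no number in this assay, only a limit of the assay: the limit of >= 40000 nM in this assay, at which 1 of the 3 values shown sits.

On the carbon with a double bond to nitrogen, 4-fluorophenyl in place of 5-fluoro-2-hydroxyphenyl gives an at least 12-fold higher number from compound 2 to compound 3 (1.10 log units; beyond the scatter), and 4-fluorophenyl in place of 2-hydroxyphenyl gives an at least 4.7-fold higher number from compound 1 to compound 3 (0.68 log units; beyond the scatter). The earlier pair had shown only a modest shift at this group on adding a fluorine, whereas this change, which removes the hydroxyl and places the fluorine differently, produces a large step, and the fluorine retained in compound 3 does not keep inhibition within reach of compound 1 or compound 2.

The hydroxyl and the fluorine change together in both steps, so the compounds shown do not separate the loss of the hydroxyl from the new place of the fluorine, and the limit leaves the full size of the loss unknown. From the compounds shown here alone, whether a methoxy group or an amine standing in place of the hydroxyl on this ring would retain inhibition also remains open.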